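A few compounds are considered here, and "the series" means these few. Any claim that something is new, unique, unknown or untested is made for them only; others in the source may bear on it.

Of the compounds shown here, three have been measured in an in vitro assay on cells for binding affinity to myelin-associated glycoprotein (Mus musculus), read by surface plasmon resonance; a higher number here means weaker binding, a lower number tighter binding. Going by the values given here, compound 1 `CC(=O)N[C@H]1[C@H]([C@@H](O)[C@H](O)CNC(=O)c2ccc(Cl)cc2)O[C@@](OCc2ccc(Cl)cc2)(C(=O)O)C[C@@H]1O` gives 15000 nM, and compound 2 `CC(=O)N[C@H]1[C@H]([C@@H](O)[C@H](O)CNC(=O)c2ccc(Cl)cc2)O[C@@](OCc2ccc3ccccc3c2)(C(=O)O)C[C@@H]1O` gives 11600 nM; the only single-site step seen, a 1.3-fold lower number from compound 1 to compound 2 (0.11 log units; within the scatter), changes the group on a saturated chain carbon bound to an oxygen. Compound 3 `O=C(NC[C@@H](O)[C@H](O)[C@@H]1O[C@@](OCc2cccc(F)c2F)(C(=O)O)C[C@H](O)[C@H]1NS(=O)(=O)c1ccccc1[N+](=O)[O-])c1ccc(Cl)cc1` gives 1400 nM, the lowest of the three numbers, and its gaps to compound 2 and to compound 1 both lie beyond the scatter. Compound 4 `O=C(CC1CC1)N[C@H]1[C@H]([C@@H](O)[C@H](O)CNC(=O)c2ccc(Cl)cc2)O[C@@](OCc2cccc(F)c2F)(C(=O)O)C[C@@H]1O` differs from compound 3 in one place: (cyclopropylmethyl)carbonyl in place of (2-nitrophenyl)sulfonyl on an amine nitrogen. Among the compounds with values here, no measured step touches that amine nitrogen. Compounds 1 and 2 carry a carbonyl group on it, as compound 4 will, while compound 3 carries the sulfonyl group, but compound 3 also differs from them at the oxygen-bound chain carbon, so the two changes cannot be separated. Compound 4 is therefore expected to show a step of a 3.6-fold higher number from compound 3 to compound 4 (0.55 log units; beyond the scatter), back toward the numbers of the carbonyl-bearing compounds. Compound 4 is estimated at 5000 nM, between 1500 nM and 15000 nM.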

Compound 4, dissociation constant: 4100 nM
Estimate against measurement, compound 4: 1.2-fold (0.09 log units) above, and the stated range covers the measured number.
By their numbers in this assay, from the lowest: compound 3; then compound 4; then compounds 2 and 1 (each within the scatter of the next).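

In this assay, going by these compounds alone, the step of a 2.9-fold higher number from compound 3 to compound 4 (0.47 log units; beyond the scatter) is the first measured change confined to the amine nitrogen, so it shows that the group on this nitrogen affects the number on its own, with the rest of the molecule held fixed. The earlier compounds shown here could not show this, as compound 3 also differed from compound 1 and compound 2 at the oxygen-bound chain carbon. The step favours (2-nitrophenyl)sulfonyl over (cyclopropylmethyl)carbonyl, but the swap changes the linking group and the ring together, so neither can be credited alone.

A (2-nitrophenyl)carbonyl group or a (cyclopropylmethyl)sulfonyl group on the same nitrogen would be needed to separate the two parts of the swap. No measurement shown here offers an explanation for the step.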